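This account rests on a few compounds, and the source may have more. Where it says the series, first, only, none or still open, it means among the compounds named here.

Measured compounds:
- compound 1 `CC(C(=O)NCc1ccc(C(C)(C)C)nc1N1CCCCCC1)c1ccc(NS(C)(=O)=O)c(F)c1` — in an assay on cells for antagonist activity at transient receptor potential cation channel subfamily V member 1 (Homo sapiens), read by FLIPR and calcium flux, with a stated time of 6 min (a higher number here means a weaker inhibitor, a lower number a stronger inhibitor), compound 1 gives 0.9 nM
- compound 2 `CCCCN(C)c1cc(C(C)(C)C)ccc1CNC(=O)C(C)c1ccc(NS(C)(=O)=O)c(F)c1` — in this assay compound 2 gives 1 nM

Compound 2 holds the higher of the two numbers, but its nearest neighbour, compound 1, sits within the scatter of it, so the two compounds cannot be ranked against each other on the numbers shown. Within the data shown here, no step between the measured compounds is available, since the two structures differ in more than one place.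

The step from compound 2 leads to compound 3 `CC(C(=O)NCc1ccc(C(C)(C)C)cc1N1CCCC1)c1ccc(NS(C)(=O)=O)c(F)c1`. The change is pyrrolidin-1-yl in place of butyl(methyl)amino on an aromatic carbon. The group sits on an aromatic carbon of a six-membered aromatic ring of carbon only, ortho to a large group and meta to a tert-butyl group.

Compound 2 and compound 1 both give low numbers although their substituents at this position differ, so the position seems to tolerate different groups. The writer expects for compound 3 no step beyond the scatter in this assay, as the estimated step of a 1.5-fold higher number from compound 2 to compound 3 (0.18 log units; within the scatter) shows. Compound 3 is therefore estimated at 1.5 nM, with a range from 0.5 nM to 5 nM.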

Compound 3, inhibition constant: 8.1 nM
Compound 3: the middle estimate sits 5.4-fold (0.73 log units) below what was measured, outside the stated range (above it).
By their numbers in this assay, from the lowest: compounds 1 and 2 (each within the scatter of the next); then compound 3.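

Replacing butyl(methyl)amino with pyrrolidin-1-yl gives an 8.1-fold higher number from compound 2 to compound 3 (0.91 log units; beyond the scatter) in this assay, so compound 3 is the weaker inhibitor of this pair. Among these compounds, this is the first comparison in which only this group changes, and it shows that the position, on an aromatic carbon ortho to a large group and meta to a tert-butyl group, does not accept every amine substituent equally, although the step is modest and compound 3 still gives 8.1 nM. Nothing available explains why an open group with no ring and a five-membered non-aromatic ring differ here.

Among the compounds shown here, the single step leaves open whether the change in number follows from closing the ring, from the size of the group, or from both. Diethylamino at this position would give an open-chain comparison for pyrrolidin-1-yl, while piperidin-1-yl would show how a larger ring behaves on the same core as compound 3.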